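Compound 4: methyl in place of amino

A few compounds are considered here, and "the series" means these few. Any claim that something is new, unique, unknown or untested is made for them only; others in the source may bear on it.

In a functional assay on MDA-MB-231 cells (Homo sapiens) for cytotoxicity, read by MTT assay, with a stated time of 48 h (on this read-out lower numbers stand for stronger inhibition and higher numbers for weaker inhibition), compound 1 (`Fc1cccc(-c2nc(Nc3ccc(Br)cc3)c3cc(F)ccc3n2)c1`) reads > 50000 nM as a limit, not a number. Compound 2 (`Oc1ccccc1Nc1nc(-c2cccc(F)c2)nc2ccc(F)cc12`) reads > 50000 nM as a limit too. Compound 3 (`Nc1ccccc1Nc1nc(-c2cccc(F)c2)nc2ccc(F)cc12`) reads > 50000 nM as a limit as well, so it has no measured number. Going by the values given here, the series so far stands at one value (the limit of > 50000 nM in this assay, at which 3 of the 3 values shown sit). Compound 4 (`Cc1ccccc1Nc1nc(-c2cccc(F)c2)nc2ccc(F)cc12`) carries methyl in place of amino on an aromatic carbon, ortho to a large group (methyl in place of amino on an aromatic carbon). The bearing steps are a step that the two limits leave unreadable from compound 2 to compound 3 and a step that the two limits leave unreadable from compound 1 to compound 3 and a step that the two limits leave unreadable from compound 1 to compound 2 and none has a readable size. The expected step is a number no higher from compound 3 to compound 4 (the limit leaves the size open) in this assay and no change beyond the scatter is expected in either direction. The estimate for compound 4 is 50000 nM (expected range 20000 nM to 100000 nM) and a further limit is the likeliest report.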

Compound 4, half-maximal inhibitory concentration: > 50000 nM
Compound 4: no number, only a limit (the forecaster's own chance of this, stated with the estimate: 80%); the middle value sits exactly at the limit.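

No step from compound 1, compound 2 or compound 3 to compound 4 can be read, because each reading is a limit and not a number: the limit of > 50000 nM in this assay, at which 4 of the 4 values shown sit.

The compounds shown leave open whether any of the four has a measurable potency in this assay, and so whether methyl, amino and hydroxy differ there.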